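Terminal Double Bond on the Hexyloxy Chain

The compounds below may be only part of what the source reports. "The series", "measured", "known", "first", "only" and "open" are said of these compounds alone.

Measured so far in an assay on isolated protein for binding affinity to leukotriene B4 receptor 1 (Homo sapiens), tested at 1 uM; on this read-out lower numbers stand for less inhibition and higher numbers for more inhibition at the one concentration tested (going by the name of the read-out):
compound 1 `C=CCc1cc(C(C)=O)c(O)cc1OCC#N`: 2%
compound 2 `C=CCc1cc(C(C)=O)c(O)cc1OCCCCCCCC#N`: 52%
compound 3 `C=CCc1cc(C(C)=O)c(O)cc1OCCCCCC`: 9%

Compound 3 sits close to compound 1 and far under compound 2; only its gap to compound 2 is beyond the scatter, so its number in this assay is lower than that of compound 2 and level with that of compound 1. Compound 4 `C=CCCCCOc1cc(O)c(C(C)=O)cc1CC=C` is the next member. The change from compound 3 is vinyl in place of ethyl on a saturated chain carbon, four bonds along the chain from an oxygen on an aromatic ring; the chain keeps its length and gains a double bond at its far end.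

Two measured steps help to judge it. The step of a number 7 percentage points higher from compound 1 to compound 3 (within the scatter) swaps one terminal group for another without a large effect. The step of a number 43 percentage points lower from compound 2 to compound 3 (beyond the scatter) removes a cyanomethyl from the end of the chain, which is a far larger change and gives a large drop. The present change is of the small kind, a terminal carbon-only swap with no acceptor gained or lost, so the expectation is no shift beyond the scatter, that is a number 3 percentage points higher from compound 3 to compound 4 (within the scatter). Compound 4 is therefore expected to give 12%, within 0% to 30%.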

Compound 4, a percentage reported as inhibition, at one concentration (the size of the read-out at that concentration, not a potency): 27%
Compound 4: middle estimate off by 15 percentage points, on the low side, and the stated range covers the measured number.
By their numbers in this assay, from the lowest: compounds 1 and 3 (each within the scatter of the next); then compound 4; then compound 2.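

The swap of ethyl for vinyl, four bonds along the chain from an oxygen on an aromatic ring, gives in this assay a number 18 percentage points higher from compound 3 to compound 4 (beyond the scatter), so the far end of this chain responds even to a change that leaves the heavy-atom count, the all-carbon make-up and the absence of hydrogen-bond donors and acceptors as they were, with one double bond as the only difference. Compound 4 also shows that a chain end without a nitrile can move clear of compound 1, with a number 25 percentage points higher from compound 1 to compound 4 (beyond the scatter), while it stays short of the long nitrile chain, with a number 25 percentage points lower from compound 2 to compound 4 (beyond the scatter). Nothing available here accounts for the effect of the double bond, so the step stands as an observation without an explanation.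

On these data alone, whether the gain is tied to a double bond in particular stays open, since a terminal alkyne, a longer chain ending in vinyl, or a hydroxyl or carboxylic acid at the same chain end could each point a different way. These readings also come from a single concentration, so how the compounds compare in potency remains unsettled.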